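Heptyl to 3,4-Dimethylbenzyl on a Shared Core

A few compounds are considered here, and "the series" means these few. Any claim that something is new, unique, unknown or untested is made for them only; others in the source may bear on it.

Compound 1 `CCCCCCCN1CCC(C(=O)Nc2cc(Cl)c(N)cc2OC)CC1` gives in a functional assay on the whole organism for antagonist activity, with Mus musculus as the target (on this read-out lower numbers stand for an effect already at smaller amounts and higher numbers for an effect only at larger amounts of compound), only a limit, > 10 mg/kg. Its two measured neighbours are likewise limits. Compound 2 `COc1cc(N)c(Cl)cc1NC(=O)C1CCN(Cc2ccccc2Cl)CC1` gives in this assay the limit > 4 mg/kg. Compound 3 `COc1cc(N)c(Cl)cc1NC(=O)C1CCN(Cc2ccc([N+](=O)[O-])cc2)CC1` gives in this assay the limit > 4 mg/kg. The steps a step that the two limits leave unreadable from compound 1 to compound 2 and a step that the two limits leave unreadable from compound 1 to compound 3 therefore cannot be sized, and the same holds for a step that the two limits leave unreadable from compound 2 to compound 3. Compound 4 `COc1cc(N)c(Cl)cc1NC(=O)C1CCN(Cc2ccc(C)c(C)c2)CC1` differs from compound 1 by 3,4-dimethylphenyl in place of hexyl on a saturated chain carbon bound to an amine nitrogen in a ring. Within the data shown here, no measured step reads on this change, since every value sits at a limit, the limit of > 10 mg/kg in this assay, at which 1 of the 3 values shown sits, or (the limit of > 4 mg/kg in this assay, at which 2 of the 3 values shown sit). Compound 4 is thus expected to stay near compound 1, with the step of a number no higher from compound 1 to compound 4 (the limit leaves the size open) expected to show no size beyond the scatter. The estimate for compound 4 is 10 mg/kg, between 3 mg/kg and 30 mg/kg, most likely again reported as a limit.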

Compound 4, dose for half-maximal effect: > 8 mg/kg
Compound 4: a limit, no number (the forecaster's own chance of this, stated with the estimate: 75%); the middle value does not contradict the limit.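

In this assay compound 4 gives > 8 mg/kg, a limit and not a number. Its steps from compound 1, compound 2 and compound 3 cannot be read. The compounds shown leave open whether exchanging these groups changes the dose for half-maximal effect at all.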